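Varying the aryl group on the shared core

The source may hold more compounds than are shown below. What is called first, only, known or untested is meant among the compounds shown, and "the series" means these compounds.

Measured so far:
compound 1 `CC(C)(C)n1cc2c(n1)C(=O)CC1(CCN(C(=O)c3cc(-c4ccccc4)nc4ccccc34)CC1)O2` gives 1940 nM
compound 2 `CC(C)(C)n1cc2c(n1)C(=O)CC1(CCN(C(=O)c3cc(-c4ccc(F)cc4)nc4ccccc34)CC1)O2` gives 5770 nM
compound 3 `CC(C)(C)n1cc2c(n1)C(=O)CC1(CCN(C(=O)c3cc(-c4ccncc4)nc4ccccc34)CC1)O2` gives 550 nM

All numbers come from a functional assay on A549 cells (Homo sapiens) for inhibition, read by MTT assay, with a stated time of 72 h; on this read-out lower numbers stand for stronger inhibition and higher numbers for weaker inhibition. Compound 1 stands second highest of the three. a 3.0-fold higher number from compound 1 to compound 2 (0.47 log units; beyond the scatter), whereas a 3.5-fold lower number from compound 1 to compound 3 (0.55 log units; beyond the scatter); a 10-fold lower number from compound 2 to compound 3 (1.02 log units; beyond the scatter).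

Compound 4 `CN1CCN(c2cc(C(=O)N3CCC4(CC3)CC(=O)c3nn(C(C)(C)C)cc3O4)c3ccccc3n2)CC1` is not yet measured. It differs from compound 1 in one place: 4-methylpiperazin-1-yl in place of phenyl on an aromatic carbon. For the measured compounds named here, no measured step puts a non-aromatic ring in this place; the nearest guide is a 3.5-fold lower number from compound 1 to compound 3 (0.55 log units; beyond the scatter), where a ring carrying nitrogen replaced phenyl and the number fell. A modest lowering or no step beyond the scatter is therefore expected, and the step expected for compound 4 is a 1.8-fold lower number from compound 1 to compound 4 (0.25 log units; within the scatter). The estimate for compound 4 is 1100 nM, in the range 350 nM to 3500 nM.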

Compound 4, half-maximal inhibitory concentration: > 10000 nM
Compound 4 ended at the assay's limit (the forecaster's own chance of this, stated with the estimate: 5%); middle value at least 9.0-fold (0.95 log units) away from the limit.
By their numbers in this assay, from the lowest: compound 3; then compound 1; then compound 2. At a limit, above all of these: compound 4.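

In this assay compound 4 gives > 10000 nM, a limit and not a number: the limit of > 10000 nM in this assay, at which 1 of the 4 values shown sits.

The fall seen with pyridin-4-yl does not carry over to every ring carrying nitrogen at this position: 4-methylpiperazin-1-yl gives an at least 5.1-fold higher number from compound 1 to compound 4 (0.71 log units; beyond the scatter) and an at least 18-fold higher number from compound 3 to compound 4 (1.25 log units; beyond the scatter). Against 4-fluorophenyl the step is an at least 1.7-fold higher number from compound 2 to compound 4 (0.23 log units; that floor lies within the scatter) and sets no order between the two compounds.

Open, from the compounds shown here alone, is whether the loss follows the non-aromatic ring or the piperazine itself. Morpholin-4-yl or a dimethylamino group here would separate these, and pyridin-3-yl would test how far the gain of compound 3 depends on where the ring nitrogen sits.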